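The source may report more compounds than this note shows. Statements on the series, on what has been measured and on what is new or still open speak of the compounds shown alone.

Three compounds share one core and differ only in the group carried on a nitrogen on an aromatic ring. Compound 1 `COc1cccc(Nc2cc3[nH]c(-c4cccc(C(F)(F)F)c4)nc3cn2)n1` gives 85000 nM in a physicochemical assay for solubility, using the shake flask method, measured as kinetic solubility, with a stated time of 20 h, at pH 2; a lower number here means a less soluble compound, a higher number a more soluble compound. Compound 2 `FC(F)(F)c1cccc(-c2nc3cnc(Nc4cccnn4)cc3[nH]2)c1` gives 161000 nM in this assay, and a 1.9-fold higher number from compound 1 to compound 2 (0.28 log units; within the scatter). Compound 3 `Fc1cnc(Nc2cc3[nH]c(-c4cccc(C(F)(F)F)c4)nc3cn2)c(F)c1` stands at < 5000 nM in this assay, which is a limit of the assay rather than a number. The two steps that lead to compound 3 were large: an at least 17-fold lower number from compound 1 to compound 3 (1.23 log units; beyond the scatter) and an at least 32-fold lower number from compound 2 to compound 3 (1.50 log units; beyond the scatter). Compound 4 `O=C(O)c1ccnc(Nc2cc3[nH]c(-c4cccc(C(F)(F)F)c4)nc3cn2)c1` carries the change (4-carboxypyridin-2-yl in place of 3,5-difluoropyridin-2-yl on a nitrogen on an aromatic ring). Since this removes the group whose entry brought those large drops, a rise beyond the scatter is expected, an at least 10-fold higher number from compound 3 to compound 4 (1.00 log units; beyond the scatter). Compound 4 is therefore estimated to give 50000 nM, with a range from 5000 nM to 250000 nM.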

Compound 4, solubility: < 5000 nM
Compound 4: a limit, no number; the forecaster's own chance of this, stated with the estimate: 20%; middle value at least 10-fold (1.00 log units) from the limit.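

At this place, on a nitrogen on an aromatic ring, a low reading is not specific to 3,5-difluoropyridin-2-yl, since 4-carboxypyridin-2-yl also gives a large drop in this assay, with an at least 32-fold lower number from compound 2 to compound 4 (1.50 log units; beyond the scatter) and an at least 17-fold lower number from compound 1 to compound 4 (1.23 log units; beyond the scatter). The result for compound 4 is a limit of the assay, not a number. The step between compound 3 and compound 4 cannot be read because both sit at the same limit: the limit of < 5000 nM in this assay, at which 2 of the 4 values shown sit. Still open, on these data alone, is whether a 4-aminopyridin-2-yl group here would give a readable number or also end at the limit.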